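Sulfur for Selenium: What to Expect of Compound 4

This account rests on a few compounds, and the source may have more. Where it says the series, first, only, none or still open, it means among the compounds named here.

Three compounds have so far been run in a functional assay on HT-29 cells (Homo sapiens) for cytotoxicity, read by MTT assay, with a stated time of 72 h; on this read-out higher numbers stand for weaker inhibition of growth and lower numbers for stronger inhibition of growth. Compound 1 `CS/C(=N\C(=O)c1cc(-c2ccccc2)nc2ccccc12)NC(=O)c1cc(-c2ccccc2)nc2ccccc12` is reported only as a limit, > 100000 nM. Compound 2 `C[Se]/C(=N\C(=O)c1sccc1Cl)NC(=O)c1sccc1Cl` likewise gives a limit, > 100000 nM. Compound 3 `CS/C(=N\C(=O)c1ccco1)NC(=O)c1ccco1` also yields a limit, > 100000 nM. Among the compounds with values here, compound 2 therefore stands where every value shown stands, at the limit of > 100000 nM in this assay, at which 3 of the 3 values shown sit, and no compound gives a number. Compound 4 `CS/C(=N\C(=O)c1sccc1Cl)NC(=O)c1sccc1Cl` has not been measured. It differs from compound 2 by a group of 2 heavy atoms (1 carbon, 1 sulfur; no ring) in place of a group of 2 heavy atoms (1 carbon, 1 selenium; no ring), on a carbon with a double bond to nitrogen. Within the data shown here, no step between measured compounds exists to show the size of such a change, so no shift beyond the usual scatter is expected in this assay in either direction. Compound 4 is accordingly expected to give about 150000 nM, within 50000 nM to 500000 nM. The step that the limit leaves unreadable from compound 2 to compound 4 is expected to be essentially flat, most likely again reported as a limit.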

Compound 4, concentration for total growth inhibition: > 100000 nM
Compound 4: no number, only a limit (the forecaster's own chance of this, stated with the estimate: 80%); the middle value lies beyond the limit too.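

Within the data shown here, compound 2 and compound 4 are both reported only as limits, and no step between them can be read. The compounds shown leave open how large the exchange of selenium for sulfur is in this assay, where none of them gives a number.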